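Swapping 2-hydroxyethyl for hydroxy on a saturated ring carbon

The compounds below may be only part of what the source reports. "The series", "measured", "known", "first", "only" and "open" are said of these compounds alone.

Compound 1 `Nc1ncc(F)c2c1ncn2[C@@H]1C[C@H](CO)[C@@H](O)[C@H]1O`: > 100000 nM
Compound 2 `Nc1ncc(F)c2c1ncn2[C@@H]1C[C@H](CCO)[C@@H](O)[C@H]1O`: > 100000 nM

Both results come from an ADME assay on MRC5 cells (Homo sapiens) for cytotoxicity; on this read-out lower numbers stand for higher toxicity in this test and higher numbers for lower toxicity in this test. Compound 2 gives > 100000 nM, which is a limit of the assay and not a number. Compound 1 stands at the same point: the limit of > 100000 nM in this assay, at which 2 of the 2 values shown sit.

Compound 3 `Nc1ncc(F)c2c1ncn2[C@@H]1C[C@H](O)[C@@H](O)[C@H]1O` carries hydroxy in place of the 2-hydroxyethyl of compound 2, on a saturated ring carbon: hydroxy in place of 2-hydroxyethyl on a saturated ring carbon. For the measured compounds named here, only one measured step bears on this change, a step that the two limits leave unreadable from compound 1 to compound 2, and it offers no size to build on. Compound 1 and compound 2 both rest at the limit, so no step beyond the usual scatter is expected in this assay, and another limit is the likeliest report. The expected change is a number no higher from compound 2 to compound 3 (the limit leaves the size open). The estimated value for compound 3 is 100000 nM, with an expected range from 40000 nM to 200000 nM.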

Compound 3, half-maximal cytotoxic concentration: > 100000 nM
Compound 3 ended at the assay's limit; the forecaster's own chance of this, stated with the estimate: 85%; the middle value lies on the limit itself.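

No step can be read among compound 1, compound 2 and compound 3, and all three give a limit rather than a number: the limit of > 100000 nM in this assay, at which 3 of the 3 values shown sit.

The compounds shown leave open whether swapping the group on this ring carbon changes toxicity in this assay at any concentration past that limit.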